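This account rests on a few compounds, and the source may have more. Where it says the series, first, only, none or still open, it means among the compounds named here.

Within the data shown here, in an ADME assay on the whole organism (Rattus norvegicus) for pharmacokinetics, read by LC-MS (a lower number here means that a smaller share of the oral dose reaches the circulation, a higher number that a larger share of the oral dose reaches the circulation), compound 1 `COc1ccc2c(c1C(=O)OCOC(C)=O)OB(O)[C@@H](Sc1nncs1)C2` gives 52%, the lower of the two numbers so far, and compound 2 `COc1ccc2c(c1C(=O)OCOC(=O)C(C)C)OB(O)[C@@H](Sc1nncs1)C2` gives 100%. Compound 3 `CCOC(=O)OCOC(=O)c1c(OC)ccc2c1OB(O)[C@@H](Sc1nncs1)C2` differs from compound 1 by one change: ethoxy in place of methyl on a carbonyl carbon, in words ethoxy in place of methyl on a carbonyl carbon. Among the measured compounds shown here, the only measured step at this place, isopropyl in place of methyl, is a number 48 percentage points higher from compound 1 to compound 2 (beyond the scatter), a large one. One step is thin support, so a rise in the same direction but of smaller size is expected. The estimated change is a number 20 percentage points higher from compound 1 to compound 3 (beyond the scatter). For compound 3 the expected value is 72%, with an estimated range from 48% to 100%.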

Compound 3, oral bioavailability: 64%
The estimate for compound 3 lay 8 percentage points above the measured number, within the range that was stated.
By their numbers in this assay, from the lowest: compound 1; then compound 3; then compound 2.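

In this assay, ethoxy in place of methyl on this carbonyl carbon gives a number 12 percentage points higher from compound 1 to compound 3 (beyond the scatter) and so shows that a second group can also raise the number. The rise is not the same for every group: ethoxy in place of isopropyl gives a number 36 percentage points lower from compound 2 to compound 3 (beyond the scatter) and places ethoxy between the other two. Nothing measured here explains why these groups differ. The compounds shown leave open what a longer carbon chain or an amine on this carbonyl carbon would do to the share of the oral dose reaching the circulation.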